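The source may report more compounds than this note shows. Statements on the series, on what has been measured and on what is new or still open speak of the compounds shown alone.

Of the compounds shown here, three with one shared core have been tested, and a fourth is still to come. Compound 1 `C=CCNC(=O)/C(C)=C(\C)c1ccc(Br)cc1` carries an allyl group on its amide-type nitrogen; in a toxicity assay on the whole organism (strain Icem-CET (SPF Caw)) for cytotoxicity, with Mus musculus as the target (on this read-out higher numbers stand for an effect only at larger amounts of compound and lower numbers for an effect already at smaller amounts), compound 1 gives 120 mg/kg. Compound 3 `C/C(C(=O)NC1CC1)=C(/C)c1ccc(Br)cc1` is built from compound 1 by one change, (cyclopropyl in place of allyl on an amide-type nitrogen), and in this assay compound 3 gives 100 mg/kg, so the step of a 1.2-fold lower number from compound 1 to compound 3 (0.08 log units; within the scatter) left the read-out essentially where it was. Compound 2 `C=CCNC(=O)/C(C)=C(/C)c1ccccc1` has a core that differs from that of compound 1; how the two cores differ is not broken down here. In this assay compound 2 gives 550 mg/kg, the highest number of the three, beyond the scatter from both others.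

Compound 4 `C/C(C(=O)NC1CC1)=C(\C)c1ccccc1` is to be made from compound 2 by the same change, (cyclopropyl in place of allyl on an amide-type nitrogen), at the same place. Since the same change from compound 1 to compound 3 moved the number only by a 1.2-fold lower number from compound 1 to compound 3 (0.08 log units; within the scatter), which is within the scatter, the step from compound 2 to compound 4 in this assay is expected to be about as small, a 1.2-fold lower number from compound 2 to compound 4 (0.07 log units; within the scatter). Compound 4 is therefore estimated at 470 mg/kg in this assay, likely between 250 mg/kg and 900 mg/kg.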

Compound 4, dose for half-maximal effect: 400 mg/kg
Compound 4: middle estimate off by 1.2-fold (0.07 log units), on the high side, within the range that was stated.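

In this assay, putting cyclopropyl in place of allyl on the amide-type nitrogen gives a 1.4-fold lower number from compound 2 to compound 4 (0.14 log units; within the scatter). Set beside the earlier case, the change carries over from one core to the other with no difference that stands out from the usual variation between repeated measurements: the same change on two cores in this assay, a 1.2-fold lower number (0.08 log units; within the scatter) from compound 1 to compound 3 and a 1.4-fold lower number (0.14 log units; within the scatter) from compound 2 to compound 4, 1.1-fold (0.06 log units) apart, within the scatter of two such steps This shows that on these two cores the swap leaves the number within the scatter, even though the two cores start from clearly different numbers; it does not show that the same would hold on any further core, as two pairs are a small basis, and it says nothing about why the swap makes so little difference or about any other read-out.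

The compounds shown leave open whether a different group on that nitrogen, such as a longer chain like hexyl or a chain ending in a carboxylic acid, would move the number beyond the scatter. They also leave open how the allyl-to-cyclopropyl change behaves on a core carrying an amine.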